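The source may report more compounds than this note shows. Statements on the series, on what has been measured and on what is new or still open speak of the compounds shown alone.

Compound 1 `NC(=O)CCc1ccc(NCc2cccc(Oc3ccccc3)c2)cc1` gives 68% in a functional assay on CHO cells for agonist activity at Free fatty acid receptor 1 (Homo sapiens), read by a luciferase reporter; a lower number here means a smaller maximal response, a higher number a larger maximal response.
Compound 2 `CN(C)C(=O)CCc1ccc(NCc2cccc(Oc3ccccc3)c2)cc1` gives 50% in this assay.
Compound 3 `Cc1nc(-c2ccc(C(F)(F)F)cc2)sc1CNc1ccc([C@H]2C[C@@H]2C(N)=O)cc1` gives 80% in this assay.

Compound 3 stands highest of the three measured, and its gaps to compound 1 and to compound 2 are both beyond the usual scatter. Compound 2 differs from compound 1 by one change, (dimethylamino in place of amino on a carbonyl carbon), and this change produced a number 18 percentage points lower from compound 1 to compound 2 (beyond the scatter). The difference between the cores of compound 1 and compound 3 is not broken down here.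

Compound 4 `Cc1nc(-c2ccc(C(F)(F)F)cc2)sc1CNc1ccc([C@H]2C[C@@H]2C(=O)N(C)C)cc1` is compound 3 with the same kind of change, (dimethylamino in place of amino on a carbonyl carbon). The surroundings are not identical: in compound 1 the carbonyl carbon's other neighbour is a saturated chain carbon, whereas in compound 3 it is a saturated ring carbon. For compound 4 a step of similar size is expected, a number 18 percentage points lower from compound 3 to compound 4 (beyond the scatter), resting on a number 18 percentage points lower from compound 1 to compound 2 (beyond the scatter). The estimated maximal response of compound 4 is 62%, most likely between 50% and 75%.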

Compound 4, largest response reached (reported as percent of maximum), in percent of the reference or control that the assay uses: 49%
Compound 4: middle estimate off by 13 percentage points, on the high side, and the stated range ends above it.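

In this assay dimethylamino in place of amino on a carbonyl carbon brings a number 31 percentage points lower from compound 3 to compound 4 (beyond the scatter) on this second core, so the change lowers the maximal response on both cores shown. The two steps do not differ by more than their scatter, so the change can be read as carrying over from one core to the other with a similar effect: the same change on two cores in this assay, a number 18 percentage points lower (beyond the scatter) from compound 1 to compound 2 and a number 31 percentage points lower (beyond the scatter) from compound 3 to compound 4, 13 percentage points apart, within the scatter of two such steps. This rests on just two pairs of compounds, and it shows neither that the step would hold on a further core nor why the response falls.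

The compounds shown leave open how methylamino on the same carbonyl carbon would compare. They also leave open what a carboxylic acid in place of the amide would give.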